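Two Small Swaps on a Shared Core

The source may hold more compounds than are shown below. What is called first, only, known or untested is meant among the compounds shown, and "the series" means these compounds.

Compound 1 `CCC(C)OC(=O)C1=C(C)NC(=O)NC1c1ccco1`: 3%
Compound 2 `CC1=C(C(=O)OC2CCC2)C(c2ccco2)NC(=O)N1`: 1%
Compound 3 `CCC(C)OC(=O)C1=C(C)NC(=O)NC1c1cccs1`: 7%

In an assay on membranes from HeLa cells for displacement of a labelled ligand from adenosine receptor A3 (Homo sapiens), read by scintillation counting, with a stated time of 180 min, tested at 1 uM (a lower number here means less inhibition, a higher number more inhibition at the concentration tested (going by the name of the read-out)), all three measured numbers are low. Compound 1 and compound 2 differ by cyclobutyl in place of sec-butyl on an oxygen next to a carbonyl group, and the step is a number 2 percentage points lower from compound 1 to compound 2 (within the scatter). Compound 1 and compound 3 differ in their cores by thiophen-2-yl in place of furan-2-yl on a saturated ring carbon, with a step of a number 4 percentage points higher from compound 1 to compound 3 (within the scatter). Compound 4 `CC1=C(C(=O)OC2CCC2)C(c2cccs2)NC(=O)N1` has not yet been measured. It differs from compound 3 by cyclobutyl in place of sec-butyl on an oxygen next to a carbonyl group, the same change as that from compound 1 to compound 2, now made on the core of compound 3. Because that earlier step was a number 2 percentage points lower from compound 1 to compound 2 (within the scatter) and compound 3 gives 7%, the step from compound 3 to compound 4 is expected to be a number 2 percentage points lower from compound 3 to compound 4 (within the scatter). Compound 4 is therefore estimated at 5%, with a likely range from -4% to 14%.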

Compound 4, a percentage reported as inhibition, at one concentration (the size of the read-out at that concentration, not a potency): 2%
Estimate against measurement, compound 4: 3 percentage points above; measured number inside the range.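

On the core of compound 3, cyclobutyl in place of sec-butyl in this assay gives a number 5 percentage points lower from compound 3 to compound 4 (within the scatter) and agrees with the earlier step: the same change on two cores in this assay, a number 2 percentage points lower (within the scatter) from compound 1 to compound 2 and a number 5 percentage points lower (within the scatter) from compound 3 to compound 4, 3 percentage points apart, within the scatter of two such steps. On the core of compound 2, thiophen-2-yl in place of furan-2-yl gives a number 1 percentage points higher from compound 2 to compound 4 (within the scatter) and also agrees with the earlier step: the same change on two cores in this assay, a number 4 percentage points higher (within the scatter) from compound 1 to compound 3 and a number 1 percentage points higher (within the scatter) from compound 2 to compound 4, 3 percentage points apart, within the scatter of two such steps. Both changes therefore look the same on either core, but with every step inside the scatter and all numbers low, this does not show that either change has a real effect that carries over.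

Still open, as far as these compounds go, is whether any group on this core gives a clear signal. An amine or a longer chain on the oxygen next to a carbonyl group could test that.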